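The compounds below may be only part of what the source reports. "The series", "measured", "known", "first", "only" and "open" are said of these compounds alone.

Two compounds of the series have a number in a functional assay on the whole organism (strain albino) with Mus musculus as the target, in the maximal electroshock model, with a stated time of 4 h; on this read-out higher numbers stand for an effect only at larger amounts of compound and lower numbers for an effect already at smaller amounts. Compound 1 `Cc1ccccc1Nc1nnc(Nc2nc(-c3ccc(Cl)cc3)cs2)s1` gives 300 mg/kg in this assay. Within the data shown here, compound 2 `Cc1ccc(Nc2nnc(Nc3nc(-c4ccc(Cl)cc4)cs3)s2)cc1` gives 100 mg/kg in this assay, the lowest of the two numbers, with the single measured step being a 3.0-fold lower number from compound 1 to compound 2 (0.48 log units; beyond the scatter).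

Compound 3 `COc1ccccc1Nc1nnc(Nc2nc(-c3ccc(Cl)cc3)cs2)s1` is not yet measured in this assay. Its change from compound 2 is 2-methoxyphenyl in place of 4-methylphenyl on a nitrogen on an aromatic ring: the 4-methylphenyl leaves and a 2-methoxyphenyl enters on the same nitrogen on an aromatic ring, carrying one hydrogen-bond acceptor where the leaving group had none. Among the measured compounds shown here, the only step that bears on this is the one from compound 1 to compound 2, in which a 2-methylphenyl was replaced by a 4-methylphenyl; compound 3 returns a substituent to the 2-position of the phenyl, though with methoxy rather than methyl, for which there is no measured pair. On that basis a higher number than compound 2 is expected for compound 3, a step of about a 2.5-fold higher number from compound 2 to compound 3 (0.40 log units; beyond the scatter), roughly reversing the measured one. Compound 3 is therefore estimated at 250 mg/kg, within 100 mg/kg to 600 mg/kg.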

Compound 3, minimum effective dose: 300 mg/kg
Compound 3: the middle estimate sits 1.2-fold (0.08 log units) below what was measured; measured number inside the range.
By their numbers in this assay, from the lowest: compound 2; then compounds 1 and 3 (each within the scatter of the next).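

In this assay the change of methyl to methoxy on an aromatic carbon gives no change at the digits printed from compound 1 to compound 3 (within the scatter), so on this read-out the 2-methoxyphenyl and the 2-methylphenyl cannot be told apart. The change of the 4-methylphenyl to the 2-methoxyphenyl gives a 3.0-fold higher number from compound 2 to compound 3 (0.48 log units; beyond the scatter), which leaves compound 2 with the lowest number of the three and both compounds with a group at the 2-position of the phenyl on higher numbers. No measurement at hand accounts for these numbers.

Open, on these data alone, is whether methoxy on the phenyl at the place where compound 2 carries its methyl would read like compound 2, which would separate the effect of place from that of group. Also open, as far as these compounds go, is how an amine, a carboxylic acid or a longer chain on this phenyl would read.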